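The compounds below may be only part of what the source reports. "The series", "measured", "known", "first", "only" and "open" are said of these compounds alone.

The series shares one core, carried by compound 3 `COc1ccc(-c2coc3cc(OCCCSC(=S)N4CCN(c5ccccn5)CC4)ccc3c2=O)cc1` alongside compound 1 `COc1ccc(-c2coc3cc(OCCCSC(=S)N4CCN(Cc5ccccc5)CC4)ccc3c2=O)cc1` and compound 2 `COc1ccc(-c2coc3cc(OCCCSC(=S)N4CCOCC4)ccc3c2=O)cc1`. In a functional assay on PC-3 cells (Homo sapiens) for inhibition, read by MTT assay, with a stated time of 48 h (a higher number here means a weaker inhibitor, a lower number a stronger inhibitor), compound 3 gives 17400 nM, the second highest of the three numbers; compound 1 gives 14900 nM and compound 2 gives 27400 nM. The step of a 1.2-fold higher number from compound 1 to compound 3 (0.07 log units; within the scatter) and the step of a 1.6-fold lower number from compound 2 to compound 3 (0.20 log units; within the scatter) both lie within the scatter, so none of the three measured compounds can be set apart from the others on these numbers.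

Compound 4 `COc1ccc(-c2coc3cc(OCCCSC(=S)N4CCN(C(=O)OC(C)(C)C)CC4)ccc3c2=O)cc1` differs from compound 3 at a single place: tert-butoxycarbonyl in place of pyridin-2-yl on an amine nitrogen in a ring. Both measured steps bear on this change. The step from compound 1 to compound 3 exchanges the group on the same amine nitrogen in a ring, and the step from compound 2 to compound 3 exchanges the whole ring attached to the thiocarbonyl carbon; neither moved the number beyond the scatter. Within the data shown here, the present exchange is of the same kind, and nothing among the measured compounds points to a different outcome, so the step of a 1.0-fold higher number from compound 3 to compound 4 (0.01 log units; within the scatter) is expected to stay within the scatter. For compound 4 the estimate in this assay is 18000 nM, with a range from 8000 nM to 40000 nM.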

Compound 4, half-maximal inhibitory concentration: 1970 nM
Beside the measured number, compound 4's estimate is 9.1-fold (0.96 log units) above it, and the stated range ends above it.
By their numbers in this assay, from the lowest: compound 4; then compounds 1, 3 and 2 (each within the scatter of the next).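

In this assay, the amine nitrogen in the six-membered non-aromatic ring proves to be a place where the number can move beyond the scatter: tert-butoxycarbonyl in place of pyridin-2-yl gives an 8.8-fold lower number from compound 3 to compound 4 (0.95 log units; beyond the scatter) and tert-butoxycarbonyl in place of benzyl gives a 7.6-fold lower number from compound 1 to compound 4 (0.88 log units; beyond the scatter) on the same nitrogen. The earlier exchange at this nitrogen, with a 1.2-fold higher number from compound 1 to compound 3 (0.07 log units; within the scatter) between two groups that each carry a six-membered aromatic ring, gave no sign of this, so among compound 1, compound 3 and compound 4 only the group without a ring stands apart. No measurement at hand bears on why this exchange lowers the number.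

The compounds shown leave open whether the lower number goes with the carbonyl or with the tert-butyl part of tert-butoxycarbonyl, a question on which an acetyl group, a methoxycarbonyl group or the bare ring amine on the same nitrogen would bear. They also leave open whether the same exchange would hold with a longer chain between the shared core and the sulfur.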